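The source may report more compounds than this note shows. Statements on the series, on what has been measured and on what is new or still open speak of the compounds shown alone.

Measured in an ADME assay on BE(2)-C cells (Homo sapiens) for cytotoxicity, read by MTT assay, with a stated time of 20 h; a higher number here means that more compound is tolerated, a lower number that less compound is tolerated:
Compound 1 `CN1CCC(CNC(=O)C2CCN(C(=O)c3cc4ccccc4n3Cc3ccc(Cl)cc3)CC2)CC1`: > 50000 nM, a limit and not a number
Compound 2 `O=C(c1cc2ccccc2n1Cc1ccc(Cl)cc1)N1CCC(C(=O)N2CCC[C@H]2CO)CC1`: 98900 nM

Going by the values given here, compound 2, at 98900 nM, holds the only actual number in this assay, so it cannot yet be ranked against anything. Compound 3 `O=C(c1cc2ccccc2n1Cc1ccc(Cl)cc1)N1CCC(C(=O)N2CCOCC2)CC1` carries morpholin-4-yl in place of 2-(hydroxymethyl)pyrrolidin-1-yl on a carbonyl carbon. Among the compounds with values here, only one measured step bears on this change, a step that the limit leaves unreadable from compound 1 to compound 2, and it has no readable size because of the limit of > 50000 nM in this assay, at which 1 of the 2 values shown sits. It also concerns a different replacement at the same carbonyl carbon. With no measured size to carry over, no step beyond the scatter is expected in this assay, and no direction is favoured. The expected step runs a 1.1-fold lower number from compound 2 to compound 3 (0.04 log units; within the scatter). For compound 3 the estimate is 90000 nM, with an expected range of 45000 nM to 180000 nM.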

Compound 3, half-maximal cytotoxic concentration: > 100000 nM
Compound 3: a limit, no number; the forecaster's own chance of this, stated with the estimate: 35%; at least 1.1-fold (0.04 log units) between middle value and limit.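

In this assay, compound 3 gives > 100000 nM, which is a limit and not a number. Morpholin-4-yl in place of 2-(hydroxymethyl)pyrrolidin-1-yl on a carbonyl carbon gives a number no lower from compound 2 to compound 3 (the limit leaves the size open), so a group with no hydrogen-bond donor and no defined stereocentre brings no lower number at this place. The size of that step and the whole step from compound 1 to compound 3 cannot be read because of a limit: the limit of > 100000 nM in this assay, at which 1 of the 3 values shown sits.

Among the compounds shown, only compound 2 holds an actual number, and none of the groups on this carbonyl carbon shows a lower one. As far as these compounds go, how a piperazine ring or a simple dimethylamino group would read at this carbonyl carbon stays open.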